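The compounds below may be only part of what the source reports. "The series", "measured", "known", "first", "only" and "open" are said of these compounds alone.

Working notes on the series. Compound 1 `O=C1N=C(O)S/C1=C\c1ccc(OCCC2CCCCC2)cc1Cl` is the reference point: in an assay for inhibition of 15-hydroxyprostaglandin dehydrogenase [NAD(+)] (Homo sapiens), read by fluorescence and spectrophotometry (a lower number here means a stronger inhibitor, a higher number a weaker inhibitor), compound 1 gives 13 nM, the lowest of the three numbers measured. Compound 2 `O=C1NC(=O)/C(=C/c2ccc(OCCOC3CCCCC3)c(Cl)c2)S1` gives 20 nM, which lies within the scatter of compound 1. Compound 3 `O=C1NC(=O)/C(=C/c2ccc(OCC3CC4CCC3C4)c(Cl)c2)S1` gives 165 nM, which lies beyond the scatter of compound 1. Among the compounds with values here, the only single-point step among the measured compounds is an 8.3-fold higher number from compound 2 to compound 3 (0.92 log units; beyond the scatter); it shows that exchanging the group at the end of the ether tail can move this assay well beyond the scatter.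

Compound 4 `O=C1N=C(O)S/C1=C\c1ccc(OCc2ccccc2)cc1Cl` differs from compound 1 by phenyl in place of cyclohexylmethyl on a saturated chain carbon bound to an oxygen on an aromatic ring. Within the data shown here, no measured pair makes an exchange of a six-membered non-aromatic ring for a six-membered aromatic ring at this place, so the step from compound 2 to compound 3 bears on it only by marking the tail as a sensitive region. For compound 4 a step toward a weaker number, smaller than that one, is the expectation: a 3.1-fold higher number from compound 1 to compound 4 (0.49 log units; beyond the scatter). Compound 4 is accordingly estimated at 40 nM, with a range from 10 nM to 160 nM.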

Compound 4, half-maximal inhibitory concentration: 487 nM
Compound 4: the middle estimate sits 12-fold (1.09 log units) below what was measured, and the stated range ends below it.
By their numbers in this assay, from the lowest: compounds 1 and 2 (each within the scatter of the next); then compound 3; then compound 4.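

In this assay, within the data shown here, a 37-fold higher number from compound 1 to compound 4 (1.57 log units; beyond the scatter) is the first reading of a ring exchange at this place, on a saturated chain carbon bound to an oxygen on an aromatic ring, and it shows that the low number of compound 1 does not carry over to a phenyl group here. Read one bond further out, the same change is 2-cyclohexylethyl to benzyl, so the ring type and the chain that holds the ring change together, and this single step cannot assign the loss to either. No measurement at hand accounts for the size of this step.

The compounds shown leave open whether a 2-phenylethyl tail, which pairs the chain of compound 1 with the aromatic ring of compound 4, would read nearer compound 1 or compound 4. A cyclohexyl group in place of the benzyl group of compound 4 would test the other half of the same question.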